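This account rests on a few compounds, and the source may have more. Where it says the series, first, only, none or still open, it means among the compounds named here.

Measured compounds:
compound 1, `CC(=O)c1c(O)ccc2oc(-c3ccccc3C)nc12` — 8940 nM
compound 2, `O=Cc1c(O)ccc2oc(-c3ccccc3Cl)nc12` — 12100 nM
compound 3, `Cc1ccccc1-c1nc2c(C=O)c(O)ccc2o1` — 12200 nM

In an ADME assay on HaCaT cells (Homo sapiens) for cytotoxicity, read by MTT assay, with a stated time of 48 h (on this read-out lower numbers stand for stronger inhibition and higher numbers for weaker inhibition), compound 3 gives the highest of the three numbers, though the steps of a 1.0-fold higher number from compound 2 to compound 3 (0.00 log units; within the scatter) and a 1.4-fold higher number from compound 1 to compound 3 (0.14 log units; within the scatter) both fall within the scatter, so the three compounds are not told apart. Compound 4, `COc1ccccc1-c1nc2c(C=O)c(O)ccc2o1`, is not yet measured. It differs from compound 3 by methoxy in place of methyl on an aromatic carbon, placed on an aromatic carbon of a six-membered aromatic ring of carbon only, ortho to a large group. A change at the same place is already known, and it was a 1.0-fold higher number from compound 2 to compound 3 (0.00 log units; within the scatter). On that basis the expected step of a 1.0-fold lower number from compound 3 to compound 4 (0.01 log units; within the scatter) is none beyond the scatter in this assay. Compound 4 is therefore estimated at 12000 nM, within 5000 nM to 30000 nM.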

Compound 4, half-maximal inhibitory concentration: 8380 nM
Compound 4: middle estimate off by 1.4-fold (0.16 log units), on the high side; low and high end bracket the measured number.
By their numbers in this assay, from the lowest: compounds 4, 1, 2 and 3 (each within the scatter of the next).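

At the aromatic carbon ortho to a large group, methoxy now joins methyl and chloro, and in this assay both a 1.5-fold lower number from compound 3 to compound 4 (0.16 log units; within the scatter) and a 1.4-fold lower number from compound 2 to compound 4 (0.16 log units; within the scatter) stay within the scatter. The position has therefore taken a group bringing an oxygen and a hydrogen-bond acceptor, with no step beyond the scatter among compounds 2, 3 and 4. No evidence on the cause of these small steps is available.

From the compounds shown here alone, whether an amine, a carboxylic acid or a longer chain at this position would give a step beyond the scatter remains open.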